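The source may hold more compounds than are shown below. What is called first, only, known or untested is meant among the compounds shown, and "the series" means these compounds.

Measured in a functional assay on A2780 cells (Homo sapiens) for inhibition, read by sulforhodamine B assay, with a stated time of 72 h (a higher number here means a weaker inhibitor, a lower number a stronger inhibitor), so far:
compound 1 `O=C(NCc1ccc(S(=O)(=O)c2ccccc2)cc1)c1nc2cnccc2[nH]1` gives 5400 nM
compound 2 `O=C(NCc1ccc(S(=O)(=O)N2CCCCC2)cc1)c1cc2ccncc2[nH]1` gives 1700 nM

Of these two, compound 2 has the lower number at 1700 nM and so is the stronger inhibitor, with a gap to compound 1 that lies beyond the usual scatter. The two compounds differ in more than one place, so this gap cannot be assigned to any single change.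

Next is compound 3 `O=C(NCc1ccc(S(=O)(=O)N2CCCCC2)cc1)c1ccn2cncc2c1` which has the same atoms as compound 2, joined differently. The change sits on a carbonyl carbon whose other neighbour is the amide-type nitrogen: a group of 9 heavy atoms (7 carbon, 2 nitrogen; one five-membered aromatic ring with 2 hetero atoms, one six-membered aromatic ring with 1 hetero atom) in place of a group of 9 heavy atoms (7 carbon, 2 nitrogen; one five-membered aromatic ring with 1 hetero atom, one six-membered aromatic ring with 1 hetero atom), on a carbonyl carbon and the rest of the molecule stays as it is.

Among the compounds with values here, no measured pair shows this exchange, so neither size nor direction has direct support. Taking compound 2 at 1700 nM as the starting point, a moderate move to a lower number in this assay is expected, beyond the scatter, though with low confidence. The expected step is a 4.3-fold lower number from compound 2 to compound 3 (0.63 log units; beyond the scatter) and it remains an estimate only. For compound 3 the estimate is 400 nM with 40 nM to 3000 nM as the expected range.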

Compound 3, half-maximal inhibitory concentration: > 10000 nM
Compound 3: no number, only a limit; the forecaster's own chance of this, stated with the estimate: 3%; middle value at least 25-fold (1.39 log units) away from the limit.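

In this assay compound 3 gives > 10000 nM, which is a limit and not a number. On the carbonyl carbon whose other neighbour is the amide-type nitrogen, the exchange gives an at least 5.8-fold higher number from compound 2 to compound 3 (0.76 log units; beyond the scatter), so activity at this place depends on how the same atoms are joined, something the earlier pair, differing in more than one place, could not show. The entering group has 0 hydrogen-bond donors and 2 hydrogen-bond acceptors against 1 of each in the group that leaves, but a single pair cannot tie the step to these counts, and the step gives only a lower bound on the change: the limit of > 10000 nM in this assay, at which 1 of the 3 values shown sits.

The compounds shown leave open whether the hydrogen-bond donor itself matters here or the ring arrangement as a whole, since the two change together in this pair. Also open, as far as these compounds go, is how a plain phenyl group, or an amine carried on the group at this carbonyl carbon, would compare with compound 2 when the rest of the molecule stays as it is.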